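This account rests on a few compounds, and the source may have more. Where it says the series, first, only, none or still open, it means among the compounds named here.

Compound 1 `O=C(O)CNC(=O)CN(c1nc(Cl)nc2[nH]cnc12)C1CC1`: 19.8%
Compound 2 `C[C@@H](O)[C@H](NC(=O)CN(c1nc(Cl)nc2[nH]cnc12)C1CC1)C(=O)O`: 37.6%
Compound 3 `CC(C)[C@H](NC(=O)CN(c1nc(Cl)nc2[nH]cnc12)C1CC1)C(=O)O`: 17.1%

These numbers come from a functional assay on the whole organism (Tail, strain ICR) with Mus musculus as the target, in the tail flick test, with a stated time of 120 min, at a dose of 25 umol/kg by the oral route; on this read-out higher numbers stand for a stronger effect at the one dose given and lower numbers for a weaker effect. Compound 3 has the lowest of the three; the step of a number 2.7 percentage points lower from compound 1 to compound 3 (within the scatter) lies within the scatter, whereas a number 20.5 percentage points lower from compound 2 to compound 3 (beyond the scatter) lies beyond it. Compound 4 `NC(=O)CC[C@H](NC(=O)CN(c1nc(Cl)nc2[nH]cnc12)C1CC1)C(=O)O` has not yet been measured. It differs from compound 3 by 2-carbamoylethyl in place of isopropyl on a saturated chain carbon bound to an amide-type nitrogen and a carbonyl carbon. The entering group brings one hydrogen-bond donor and one acceptor; compound 2, whose side chain is the 1-hydroxyethyl, is the strongest of the measured three. Among the compounds with values here, the steps that bear on the change are a number 17.8 percentage points higher from compound 1 to compound 2 (beyond the scatter) and a number 20.5 percentage points lower from compound 2 to compound 3 (beyond the scatter), both modest. A modest rise is therefore expected, a number 10.9 percentage points higher from compound 3 to compound 4 (beyond the scatter). The estimate for compound 4 in this assay is 28%, ranging from 14% to 42%.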

Compound 4, a percentage reported as activity, at one dose (the size of the read-out at that dose, not a potency): 17.8%
Estimate against measurement, compound 4: 10.2 percentage points above; the range from low to high includes it.
By their numbers in this assay, from the lowest: compounds 3, 4 and 1 (each within the scatter of the next); then compound 2.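

At this saturated chain carbon in this assay the hydrogen-bond donor and acceptor of 2-carbamoylethyl brought no gain (the step is a number 0.7 percentage points higher from compound 3 to compound 4 (within the scatter) and, against hydrogen, a number 2 percentage points lower from compound 1 to compound 4 (within the scatter)). The 1-hydroxyethyl of compound 2 therefore remains apart from all three other compounds, also from the new one (the step is a number 19.8 percentage points lower from compound 2 to compound 4 (beyond the scatter)). Nothing available here explains this difference between the two side chains.

Going by these compounds, whether a hydroxymethyl, a carbamoylmethyl, an amine or a carboxylic acid on this carbon would reach the number of compound 2 remains open.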